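The source may report more compounds than this note shows. Statements on the series, on what has been measured and on what is new or still open speak of the compounds shown alone.

Measured compounds:
- compound 1, `O=C(NC1CCN(C2CC2)C1)c1cc(-c2ccc(NS(=O)(=O)c3cccc(Cl)c3Cl)cc2)nc2[nH]ncc12`: 6 nM
- compound 2, `O=C(NC1CCN(CC2CC2)C1)c1cc(-c2ccc(NS(=O)(=O)c3cccc(Cl)c3Cl)cc2)nc2[nH]ncc12`: 1 nM
- compound 3, `NC(=O)c1cc(-c2ccc(NS(=O)(=O)c3cccc(Cl)c3Cl)cc2)nc2[nH]ncc12`: 1 nM

Going by the values given here, in an assay for inhibition of serine/threonine-protein kinase Sgk1 (Homo sapiens), with stated times of 30 min and 60 min, in the presence of a further agent that is not named here (on this read-out higher numbers stand for weaker inhibition and lower numbers for stronger inhibition), compound 3 stands level with compound 2, the two lowest numbers of the three; the step of no change at the digits printed from compound 2 to compound 3 (within the scatter) lies within the scatter, while a 6.0-fold lower number from compound 1 to compound 3 (0.78 log units; beyond the scatter) is the only step beyond it. Compound 4, `CC(C)NC(=O)c1cc(-c2ccc(NS(=O)(=O)c3cccc(Cl)c3Cl)cc2)nc2[nH]ncc12`, differs from compound 3 by isopropyl in place of hydrogen on an amide-type nitrogen. Both measured steps bear on this site: removing the larger ring-bearing group gave a 6.0-fold lower number from compound 1 to compound 3 (0.78 log units; beyond the scatter) in one case and no change in the other, so a substituent on this amide nitrogen has so far cost nothing or a modest amount. For the smaller isopropyl group, little movement is expected, perhaps a slight rise. Compound 4 is therefore estimated at 2 nM, within 0.7 nM to 6 nM. This estimate corresponds to an expected step of a 2.0-fold higher number from compound 3 to compound 4 (0.30 log units; within the scatter).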

Compound 4, half-maximal inhibitory concentration: 68 nM
Beside the measured number, compound 4's estimate is 34-fold (1.53 log units) below it; the measured number lies above the stated range.
By their numbers in this assay, from the lowest: compounds 2 and 3 (each within the scatter of the next); then compound 1; then compound 4.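

In this assay a substituent on this amide-type nitrogen is not free of cost: isopropyl in place of hydrogen gives a large rise (a 68-fold higher number from compound 3 to compound 4 (1.83 log units; beyond the scatter)). The rise does not follow the number of heavy atoms added, since the larger ring-bearing groups give lower numbers than isopropyl (a 68-fold higher number from compound 2 to compound 4 (1.83 log units; beyond the scatter); an 11-fold higher number from compound 1 to compound 4 (1.05 log units; beyond the scatter)). No measurement shown accounts for this difference.

On these data alone, it remains open whether methyl or ethyl on this nitrogen already raises the number. As far as these compounds go, it is also open whether an open chain carrying an amine, such as 2-aminoethyl, would match compound 2.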